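The compounds below may be only part of what the source reports. "The series", "measured", "known", "first", "only" and "open" are said of these compounds alone.

In a functional assay on KYSE-450 cells (Homo sapiens) for inhibition, read by CCK-8 assay, with a stated time of 48 h (a lower number here means a stronger inhibitor, a higher number a weaker inhibitor), compound 1 `COc1cc(N(Cc2ccc(Br)cc2)C(=O)CSC(=S)N2CCN(C(=O)OC(C)(C)C)CC2)cc(OC)c1OC`, which carries a 4-bromophenyl group, gives 10700 nM. Compound 2 `COc1ccc(CN(C(=O)CSC(=S)N2CCN(C(=O)OC(C)(C)C)CC2)c2cc(OC)c(OC)c(OC)c2)cc1F`, with 3-fluoro-4-methoxyphenyl in that place, gives 2410 nM, which is a 4.4-fold lower number from compound 1 to compound 2 (0.65 log units; beyond the scatter). Compound 3 `COc1ccc(CN(C(=O)CSC(=S)N2CCN(C(=O)OC(C)(C)C)CC2)c2cc(OC)c(OC)c(OC)c2)cc1C`, with 4-methoxy-3-methylphenyl, gives > 20000 nM, and this is a limit of the assay, not a number. Compared with the bromo compound, its standing is only loosely fixed, at an at least 1.8-fold higher number from compound 1 to compound 3 (0.27 log units; that floor lies within the scatter). Against the fluoro compound it is clearer, at an at least 8.2-fold higher number from compound 2 to compound 3 (0.91 log units; beyond the scatter).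

The next structure is compound 4 `COc1ccc(CN(C(=O)CSC(=S)N2CCN(C(=O)OC(C)(C)C)CC2)c2cc(OC)c(OC)c(OC)c2)cc1[N+](=O)[O-]`, which has nitro in place of methyl on an aromatic carbon, turning 4-methoxy-3-methylphenyl into 4-methoxy-3-nitrophenyl (nitro in place of methyl on an aromatic carbon). For the measured compounds named here, no measured compound carries a nitro group, so the closest guide is the change of group on that same aromatic carbon, seen in an at least 8.2-fold higher number from compound 2 to compound 3 (0.91 log units; beyond the scatter). That step shows that the group there can move the reading by a clear margin, and compound 3 sits at the weak end. A move to a lower number in this assay is therefore expected, probably of modest size, with the reading of compound 4 expected to stay higher than that of compound 2 at 2410 nM. The expected step is an at least 3.3-fold lower number from compound 3 to compound 4 (0.52 log units; beyond the scatter). For compound 4 the estimated value is 6000 nM, with an expected range from 1500 nM to 20000 nM.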

Compound 4, half-maximal inhibitory concentration: 810 nM
For compound 4 the middle estimate is 7.4-fold (0.87 log units) above the measured one; measured number outside the range, below it.
By their numbers in this assay, from the lowest: compound 4; then compound 2; then compound 1. At a limit, above all of these: compound 3.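

Compound 4 is the strongest inhibitor of the four in this assay, so this aromatic carbon, ortho to a methoxy group, can do more than separate a weak compound from a moderate one: nitro in place of methyl gives an at least 24-fold lower number from compound 3 to compound 4 (1.39 log units; beyond the scatter), and nitro in place of fluoro gives a 3.0-fold lower number from compound 2 to compound 4 (0.47 log units; beyond the scatter). The first of these steps is only a floor, since compound 3 stands at a limit of the assay and not at a number: the limit of > 20000 nM in this assay, at which 1 of the 4 values shown sits. Against the bromo compound, the 4-methoxy-3-nitrophenyl group gives a 13-fold lower number from compound 1 to compound 4 (1.12 log units; beyond the scatter), and the reading does not simply worsen with the heavy-atom count of the group here, as methyl, with 1 heavy atom, sits at the weak end and nitro, with 3, at the strong end.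

The compounds shown leave open whether this low reading is particular to nitro or would also come with a nitrile, a trifluoromethyl group or an amine on the same carbon. They also leave open whether the nitro step would hold if a hydroxyl group took the place of the methoxy group.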